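The source may report more compounds than this note shows. Statements on the series, on what has been measured and on what is new or still open speak of the compounds shown alone.

In an ADME assay on Huh-5-2 cells (Homo sapiens) for cytotoxicity, read by MTT assay, with a stated time of 72 h (a higher number here means that more compound is tolerated, a lower number that less compound is tolerated), compound 1 `CN(C)c1ccc(/C=C2\C(=O)N(c3ncc(-c4ccc(Cl)cc4)s3)N=C2c2ccccc2)cc1` gives > 206000 nM, which is a limit of the assay and not a number. Going by the values given here, compound 2 `CCOC(=O)c1ccc(/C=C2/C=C(c3ccccc3)N(c3ccccc3)C2=O)cc1` gives 112000 nM, the only actual number so far in this assay. Compound 3 `COc1ccc(/C=C2/C=C(c3ccccc3)N(c3ccccc3)C2=O)cc1` differs from compound 2 in one place: it has methoxy in place of ethoxycarbonyl on an aromatic carbon, para to a large group (methoxy in place of ethoxycarbonyl on an aromatic carbon). Among the compounds with values here, no measured pair shows this kind of change. In this assay, no step beyond the usual scatter is expected, in either direction. Compound 3 is expected to give 100000 nM, with an estimated range of 40000 nM to 220000 nM.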

Compound 3, half-maximal cytotoxic concentration: 97200 nM
Compound 3: middle estimate off by 1.0-fold (0.01 log units), on the high side, and the stated range covers the measured number.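

Going by these compounds alone, this is the first measured change at this position, an aromatic carbon para to a large group: in this assay, methoxy in place of ethoxycarbonyl brings a 1.2-fold lower number from compound 2 to compound 3 (0.06 log units; within the scatter). The two groups differ in heavy atoms and hydrogen-bond acceptors, yet this one pair shows no step beyond the scatter. Nothing shown here bears on why that is. On these data alone, it remains open whether an amine or a carboxylic acid on this carbon would move the number beyond the scatter. This single pair also cannot show whether the same change would behave alike on another core.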